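Amide heterocycle swap on the phenyl sulfone benzylamide series

The compounds below may be only part of what the source reports. "The series", "measured", "known", "first", "only" and "open" are said of these compounds alone.

Compound 1 `O=C(NCc1ccc(S(=O)(=O)c2ccccc2)cc1)c1cc2ncccc2s1` is the unsubstituted phenyl sulfone member of the set. In a functional assay on A2780 cells (Homo sapiens) for inhibition, read by sulforhodamine B assay, with a stated time of 72 h (on this read-out lower numbers stand for stronger inhibition and higher numbers for weaker inhibition), compound 1 gives only a limit, > 10000 nM, so no number is known for it. Compound 1 stands at the weak end of the three results shown, as the limit of > 10000 nM in this assay, at which 1 of the 3 values shown sits, records. The two compounds with other amide heterocycles are potent: compound 2 `Cc1cccc(S(=O)(=O)c2ccc(CNC(=O)c3cc4cnccc4[nH]3)cc2)c1` gives 4 nM in this assay, and compound 3 `O=C(NCc1ccc(S(=O)(=O)c2cccc(C(F)(F)F)c2)cc1)c1cnc2nccn2c1` gives 2 nM; these two values lie within the usual scatter of each other.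

Compound 4 `O=C(NCc1ccc(S(=O)(=O)c2ccccc2)cc1)c1cn2ccnc2cn1` is not yet measured. It differs from compound 1 in one place: a group of 9 heavy atoms (6 carbon, 3 nitrogen; one five-membered aromatic ring with 2 hetero atoms, one six-membered aromatic ring with 2 hetero atoms) in place of a group of 9 heavy atoms (7 carbon, 1 nitrogen, 1 sulfur; one five-membered aromatic ring with 1 hetero atom, one six-membered aromatic ring with 1 hetero atom), on a carbonyl carbon. The sulfone side stays as in compound 1.

For the measured compounds named here, no measured pair differs in exactly this way, so the size of the step is uncertain. The entering group brings compound 4 closer to the amide heterocycle of compound 3, which gives 2 nM, while the plain phenyl sulfone of compound 1 is retained. A gain well beyond the scatter is expected, though smaller than the gap from compound 1 to compound 3. For compound 4 the expected value in this assay is 30 nM, with a range from 3 nM to 300 nM. This estimate implies a step of an at least 330-fold lower number from compound 1 to compound 4 (2.52 log units; beyond the scatter).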

Compound 4, half-maximal inhibitory concentration: > 10000 nM
Compound 4: no number, only a limit; the forecaster's own chance of this, stated with the estimate: 15%; middle value at least 330-fold (2.52 log units) from the limit.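

Compound 1 and compound 4 both stand only as limits in this assay, so the step between them cannot be read. The compounds shown leave open whether these two amide heterocycles differ at all, and what either would give with the sulfone side of compound 2 or compound 3.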